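From a Methyl to a Carboxymethyl Group

A few compounds are considered here, and "the series" means these few. Any claim that something is new, unique, unknown or untested is made for them only; others in the source may bear on it.

In a functional assay on TSGH cells (Homo sapiens) for inhibition, with a stated time of 72 h (on this read-out lower numbers stand for stronger inhibition and higher numbers for weaker inhibition), compound 1 `COc1cc(C(=O)c2ccc3cc[nH]c3c2)cc(OC)c1OC` gives 430 nM while compound 2 `COc1cc(C(=O)c2ccc3c(ccn3C)c2)cc(OC)c1OC` gives 13.4 nM as the lower of the two numbers, with a gap beyond the usual scatter. Compound 3 `COc1cc(C(=O)c2ccc3c(ccn3CC(=O)O)c2)cc(OC)c1OC` differs from compound 2 by a single change (carboxy in place of hydrogen on a saturated chain carbon bound to an aromatic nitrogen) with carboxy in place of hydrogen on a saturated chain carbon bound to an aromatic nitrogen. For the measured compounds named here, no measured pair shows this change. In this assay the expected result is a large move towards weaker inhibition, well beyond the scatter, and the expected size is a 60-fold higher number from compound 2 to compound 3 (1.78 log units; beyond the scatter) on this reading. Compound 3 is estimated at 800 nM (range 100 nM to 6000 nM).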

Compound 3, half-maximal inhibitory concentration: 548 nM
Beside the measured number, compound 3's estimate is 1.5-fold (0.16 log units) above it; the measured number falls inside the stated range.
By their numbers in this assay, from the lowest: compound 2; then compounds 1 and 3 (each within the scatter of the next).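

In this assay, this position on the saturated chain carbon bound to an aromatic nitrogen does not tolerate every change: carboxy in place of hydrogen brings a 41-fold higher number from compound 2 to compound 3 (1.61 log units; beyond the scatter) on the shared core. Methyl to carboxymethyl is therefore a large step towards weaker inhibition. Nothing available here accounts for its size. The compounds shown leave open whether a methyl ester, a primary amide, an amine or a longer chain ending in a carboxylic acid would read closer to compound 2 or to compound 3.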